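The compounds below may be only part of what the source reports. "The series", "measured", "known", "first", "only" and "open" are said of these compounds alone.

Of the compounds shown here, three with the same shared core have been measured in a functional assay on CAL-51 cells (Homo sapiens) for inhibition, read by sulforhodamine B assay, with a stated time of 3 days; on this read-out lower numbers stand for stronger inhibition of growth and higher numbers for weaker inhibition of growth. Compound 1 `O=C(/C=C/c1ccc(OCc2ccccc2)cc1)c1ccccc1` gives 24700 nM, compound 2 `O=C(/C=C/c1ccc(Cl)cc1)c1ccccc1` gives 5850 nM and compound 3 `O=C(/C=C/c1cccc([N+](=O)[O-])c1)c1ccccc1` gives 1080 nM. Compound 2 therefore stands second highest of the three numbers, with compound 1 above it and compound 3 below. Compound 4 `O=C(/C=C/c1ccc(Cl)cc1)c1ccc(OCc2ccccc2)cc1` differs from compound 2 in one place: benzyloxy in place of hydrogen on an aromatic carbon. Within the data shown here, the only measured step, a 4.2-fold lower number from compound 1 to compound 2 (0.63 log units; beyond the scatter), concerns a benzyloxy on the other ring of the core, so it bears on this change only indirectly, and no measured pair shows a benzyloxy entering where it enters in compound 4. The account therefore expects a 1.2-fold higher number from compound 2 to compound 4 (0.08 log units; within the scatter), a step hardly beyond the scatter and more likely upward than downward. For compound 4 the estimate is 7000 nM, within 2500 nM to 20000 nM.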

Compound 4, concentration for 50% growth inhibition: > 50000 nM
Compound 4 gave a limit, no number (the forecaster's own chance of this, stated with the estimate: 5%); middle value at least 7.1-fold (0.85 log units) from the limit.
By their numbers in this assay, from the lowest: compound 3; then compound 2; then compound 1. At a limit, above all of these: compound 4.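

In this assay compound 4 gives a limit and not a number: the limit of > 50000 nM in this assay, at which 1 of the 4 values shown sits. Benzyloxy in place of hydrogen on this aromatic carbon, para to a large group, gives an at least 8.5-fold higher number from compound 2 to compound 4 (0.93 log units; beyond the scatter), the first measured step at this position, and it runs toward weaker inhibition of growth. The limit fixes only the least size of this step, not its full size. As far as these compounds go, whether a hydroxyl, a methoxy or an amine on the same carbon would keep the number close to that of compound 2 remains open.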